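A few compounds are considered here, and "the series" means these few. Any claim that something is new, unique, unknown or untested is made for them only; others in the source may bear on it.

Values measured in an ADME assay on MT4 cells (Homo sapiens) for cytotoxicity, read by MTT assay (on this read-out higher numbers stand for lower toxicity in this test and lower numbers for higher toxicity in this test), are as follows:

- compound 1 (`O=C1c2ccccc2C(=O)N1CCOC(=S)N(C(=O)c1cccc(F)c1F)c1ccc(Cl)cc1`) gives 58000 nM in this test
- compound 2 (`O=C1c2ccccc2C(=O)N1CCOC(=S)N(C(=O)c1ccc(F)cc1F)c1ccc(Cl)cc1`) gives 52000 nM in this test
- compound 3 (`O=C1c2ccccc2C(=O)N1CCOC(=S)N(C(=O)c1cccc(Cl)c1Cl)c1ccc(Cl)cc1`) gives 54000 nM in this test

Compound 3 lies within the usual scatter of both other compounds, so these three numbers cannot be told apart. The next compound, compound 4 (`COc1cccc(OC)c1C(=O)N(C(=S)OCCN1C(=O)c2ccccc2C1=O)c1ccc(Cl)cc1`), keeps the shared core and differs from compound 3 in one group. The change is 2,6-dimethoxyphenyl in place of 2,3-dichlorophenyl on a carbonyl carbon and it puts 2,6-dimethoxyphenyl in place of 2,3-dichlorophenyl on a carbonyl carbon. The entering group carries oxygen, whereas the leaving group carries chlorine.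

For the measured compounds named here, three measured steps bear on this change, since all of them swap the group at that same place. The first is a 1.1-fold lower number from compound 1 to compound 2 (0.05 log units; within the scatter) and the second is a 1.1-fold lower number from compound 1 to compound 3 (0.03 log units; within the scatter) and the third is a 1.0-fold higher number from compound 2 to compound 3 (0.02 log units; within the scatter) and none goes beyond the scatter. Going by the values given here, those swaps only exchange one fluorine- or chlorine-bearing group for another, and no measured compound carries a 2,6-dimethoxyphenyl, so they are only a loose guide. The estimated step, a 1.0-fold lower number from compound 3 to compound 4 (0.02 log units; within the scatter), is expected to stay within the scatter of this assay and to show no clear direction. For compound 4 the estimated value is 52000 nM with an expected range from 25000 nM to 100000 nM in this test.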

Compound 4, half-maximal cytotoxic concentration: 69000 nM
The estimate for compound 4 lay 1.3-fold (0.12 log units) below the measured number; the measured number falls inside the stated range.
By their numbers in this assay, from the lowest: compounds 2, 3, 1 and 4 (each within the scatter of the next).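

In this assay, putting 2,6-dimethoxyphenyl on the carbonyl carbon in place of the fluorine- or chlorine-bearing groups gives a 1.3-fold higher number from compound 3 to compound 4 (0.11 log units; within the scatter) and a 1.3-fold higher number from compound 2 to compound 4 (0.12 log units; within the scatter) and a 1.2-fold higher number from compound 1 to compound 4 (0.08 log units; within the scatter) and all three steps stay within the scatter. The earlier compounds shown here only exchanged one fluorine- or chlorine-bearing group for another, whereas this change brings in a group that carries oxygen and has hydrogen-bond acceptors, and the read-out still shows no clear shift, so all four compounds remain indistinguishable in this test. No measurement shown here offers an explanation for this flat result.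

The compounds shown leave open whether a group of a different kind on this carbonyl carbon, such as a phenyl ring bearing a carboxylic acid or an amine, or a longer chain in place of the ring, would also stay within the scatter. They also leave open whether any group at this place can move the number clearly in either direction in this assay at all.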